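Series notes: from compound 1 to compound 4

A few compounds are considered here, and "the series" means these few. Any claim that something is new, unique, unknown or untested is made for them only; others in the source may bear on it.

Measured in an ADME assay on microsomes from liver (Rattus norvegicus) for metabolic stability, read by LC-MS, using NADPH, with a stated time of 10 min, tested at 0.1 uM; on this read-out lower numbers stand for slow clearance and higher numbers for fast clearance:
- compound 1 `COc1ccc(F)cc1N1C(=O)CSC1c1cccc(C(=O)NCCCCn2cccn2)c1` gives 1470 mL.min-1.g-1
- compound 2 `COc1ccc(F)cc1N1C(=O)CSC1c1cccc(C(=O)NCCCCc2ccccc2)c1` gives 2300 mL.min-1.g-1
- compound 3 `C#Cc1cc(C(=O)NCCCCc2ccccc2)cc(C2SCC(=O)N2c2ccccc2OC)c1` gives 2200 mL.min-1.g-1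

The three values lie within the usual scatter of one another, so the numbers do not set compound 1 apart from compound 2 or compound 3. Compound 4 `Cc1ccnc(N2C(=O)CSC2c2cccc(C(=O)NCCCCn3cccn3)c2)c1` is still unmeasured. Its difference from compound 1 is 4-methylpyridin-2-yl in place of 5-fluoro-2-methoxyphenyl on an amide-type nitrogen in a ring and it falls on the amide-type nitrogen in a ring. Within the data shown here, no measured pair shows a change at that place. Among the measured compounds shown here, the one measured step is a 1.6-fold higher number from compound 1 to compound 2 (0.19 log units; within the scatter) and it lies within the scatter, but it concerns the group on the saturated chain, so it bears on the new change only indirectly. With nothing else to go on, the expectation rests on compound 1 at 1470 mL.min-1.g-1 and carries a wide range. The estimated step is a 1.2-fold lower number from compound 1 to compound 4 (0.09 log units; within the scatter) in this assay and no step beyond the scatter is expected. Compound 4 is expected at 1200 mL.min-1.g-1 with an estimated range from 500 mL.min-1.g-1 to 2600 mL.min-1.g-1 for now.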

Compound 4, intrinsic clearance in microsomes: 1020 mL.min-1.g-1
The estimate for compound 4 lay 1.2-fold (0.07 log units) above the measured number; the range from low to high includes it.
By their numbers in this assay, from the lowest: compounds 4, 1, 3 and 2 (each within the scatter of the next, the first and the last beyond it).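

Among these compounds, at the amide-type nitrogen in the ring, the first measured change in this assay is 4-methylpyridin-2-yl in place of 5-fluoro-2-methoxyphenyl, which gives a 1.4-fold lower number from compound 1 to compound 4 (0.16 log units; within the scatter). On this read-out, an aromatic ring of carbon only can therefore give way to one with a hetero atom at this place, with the fluoro and methoxy substituents gone, without a step beyond the scatter. Nothing available here speaks to why the step has this size.

Still open, going by these compounds, is whether an unsubstituted pyridin-2-yl or a saturated cyclohexyl group on the same nitrogen would give a step beyond the scatter. On these data alone, it is also open whether 4-methylpyridin-2-yl would give a similar step with phenyl on the chain in place of 1H-pyrazol-1-yl, as in compound 2.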